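This account rests on a few compounds, and the source may have more. Where it says the series, first, only, none or still open, it means among the compounds named here.

Working notes on the series. For the measured compounds named here, in an ADME assay on S9 fraction from liver (Rattus norvegicus) for metabolic stability, read by LC-MS, using NADPH, with a stated time of 30 min (a higher number here means that more of the compound is left, a lower number that less of the compound is left), compound 3 `CCCCCCCCc1ccc(OC(C)C(=O)Cn2nnc(-c3ccc(C(=O)O)cc3)n2)cc1` gives 55%, the only numerical value among the three measured compounds. Compound 1 `CC(Oc1ccc(Oc2ccc(F)cc2)cc1)C(=O)Cn1nnc(-c2ccc(Cl)cc2)n1` gives < 5% in this assay, which is a limit of the assay and not a number. Compound 2 `COC(=O)c1ccc(-c2nnn(CC(=O)C(C)Oc3ccc(Oc4ccc(F)cc4)cc3)n2)cc1` gives < 5% in this assay, again a limit and not a number. The step that the two limits leave unreadable from compound 1 to compound 2 is therefore unreadable, as both ends sit at the limit of < 5% in this assay, at which 2 of the 3 values shown sit.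

Compound 4 `CC(Oc1ccc(Oc2ccc(F)cc2)cc1)C(=O)Cn1nnc(-c2ccc(C(=O)O)cc2)n1` is to be measured in this assay. It differs from compound 3 by 4-fluorophenoxy in place of octyl on an aromatic carbon, so that compound 4 carries the same 4-fluorophenoxy group found in compound 1 and compound 2 together with the carboxylic acid of compound 3. Going by the values given here, no measured step covers this exchange, so its size is not known. Among the compounds with values here, both compounds bearing the 4-fluorophenoxy group, compound 1 and compound 2, sit at the limit of < 5% in this assay, at which 2 of the 3 values shown sit, while compound 3 with the octyl group is the one compound that gives a number. On that basis compound 4 is expected to fall well short of compound 3, a step of a number 40 percentage points lower from compound 3 to compound 4 (beyond the scatter) estimated as downward and beyond the scatter. Compound 4 is estimated at 15%, within 3% to 40%, with a fair chance that only a limit is reported.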

Compound 4, percent of the compound remaining: 33%
Compound 4: the middle estimate sits 18 percentage points below what was measured; the range from low to high includes it.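

In this assay, carboxy in place of chloro gives a number at least 28 percentage points higher from compound 1 to compound 4 (beyond the scatter), and the carboxylic acid in place of the methyl ester gives a number at least 28 percentage points higher from compound 2 to compound 4 (beyond the scatter), so the 4-fluorophenoxy group no longer rules out a measured number among these compounds. At the aromatic carbon para to a large group, 4-fluorophenoxy in place of octyl gives a number 22 percentage points lower from compound 3 to compound 4 (beyond the scatter), a modest step that leaves compound 4 with a number. Compound 1 and compound 2 each sit at a limit and not a number, so the two steps from them give only a minimum size: the limit of < 5% in this assay, at which 2 of the 4 values shown sit.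

Going by these compounds, whether a primary amide or an amine in place of the carboxylic acid would also give a number remains open. So does the outcome of a shorter chain than octyl at this position.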